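Series notes: cyclopropyl swapped for a carbamate-bearing chain

The compounds below may be only part of what the source reports. "The series", "measured", "known", "first", "only" and "open" are said of these compounds alone.

Among the compounds with values here, compound 2 `O=C(Nc1ccc(NCC2CC2)cc1Cl)c1cc(Cl)ccc1O` stands lowest of the two numbers so far in an ADME assay on A549 cells (Homo sapiens) for cytotoxicity, read by resazurin assay, with a stated time of 48 h (a lower number here means that less compound is tolerated, a higher number that more compound is tolerated), with compound 2 giving 14400 nM. Compound 3 `O=C(Nc1ccc(N(CCCO)CCCO)cc1Cl)c1cc(Cl)ccc1O` gives 114000 nM in this assay, and the step of a 7.9-fold higher number from compound 2 to compound 3 (0.90 log units; beyond the scatter) is the only measured one on hand. Compound 1 `CC(=O)Nc1ccc(NC(=O)c2cc(Cl)ccc2O)c(Cl)c1` shares the core, but for compound 1 this assay records "not determined" (no result reported).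

Compound 4 `CC(C)(C)OC(=O)NCCNc1ccc(NC(=O)c2cc(Cl)ccc2O)c(Cl)c1` differs from compound 2 by ((tert-butoxycarbonyl)amino)methyl in place of cyclopropyl on a saturated chain carbon bound to a nitrogen on an aromatic ring. Within the data shown here, the one measured step that bears on this change is the one from compound 2 to compound 3, where a chain carrying hydrogen-bond donors and acceptors replaced the (cyclopropylmethyl)amino group and the number rose. Compound 4 also gains a hydrogen-bond donor and two acceptors at the place on a saturated chain carbon bound to a nitrogen on an aromatic ring, though by a different group, so a rise of smaller size is expected. For compound 4 the step is estimated as a 2.4-fold higher number from compound 2 to compound 4 (0.39 log units; beyond the scatter). In this assay compound 4 is therefore expected to give about 35000 nM, with a range from 12000 nM to 100000 nM.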

Compound 4, half-maximal cytotoxic concentration: 25000 nM
Compound 4: the middle estimate sits 1.4-fold (0.15 log units) above what was measured; low and high end bracket the measured number.
By their numbers in this assay, from the lowest: compounds 2 and 4 (each within the scatter of the next); then compound 3.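

Replacing cyclopropyl with ((tert-butoxycarbonyl)amino)methyl on a saturated chain carbon bound to a nitrogen on an aromatic ring gives a 1.7-fold higher number from compound 2 to compound 4 (0.24 log units; within the scatter) in this assay, so at this place, losing the ring and adding a larger group with hydrogen-bond donor and acceptors does not by itself separate the pair. Any link between such a chain and a higher number therefore does not hold across the series: compound 3 fits it with a 7.9-fold higher number from compound 2 to compound 3 (0.90 log units; beyond the scatter), while compound 4 goes against it. No measurement given here explains why the two changes read differently.

From the compounds shown here alone, whether a free amine or a carboxylic acid at the end of the chain would carry the number beyond the scatter remains open. Also open, going by these compounds, is whether a longer chain on the same nitrogen would do so.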